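Swapping Chloro for Fluoro in Compound 1

This account rests on a few compounds, and the source may have more. Where it says the series, first, only, none or still open, it means among the compounds named here.

- compound 1 `Nc1ccccc1NC(=O)/C=C/c1ccc(CSc2ccc(Cl)cc2)cc1`: 48.2%
- compound 2 `COc1ccc(SCc2ccc(C(=O)Nc3ccccc3N)cc2)cc1`: 81.8%
- compound 3 `Nc1ccccc1NC(=O)c1ccc(CSc2cccc(F)c2)cc1`: 76.3%
- compound 4 `Nc1ccccc1NC(=O)/C=C/c1ccc(CSc2ccc(F)cc2)cc1`: not yet measured

In a functional assay on A-375 cells (Homo sapiens) for inhibition, read by CCK-8 assay, with a stated time of 72 h, tested at 8 uM (a lower number here means less inhibition of growth, a higher number more inhibition of growth at the concentration tested), compound 1 gives 48.2%, the lowest of the three numbers and clearly under both of the others. The next compound to test, compound 4, differs from compound 1 in a single place: fluoro in place of chloro on an aromatic carbon. The swap lies para to a large group, and the rest of the molecule stays the same.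

Within the data shown here, no measured pair shows this exact swap. The closest evidence is a number 5.5 percentage points lower from compound 2 to compound 3 (within the scatter), where one group on the sulfur replaces another and the number does not move beyond the usual scatter. That pair suggests this part of the molecule can tolerate a change, though it involves different groups. Compound 2 and compound 3 also have a different core from compound 1 and compound 4, so their higher values should not be carried over.

The swap is therefore expected to leave the number about where it is, with no step beyond the scatter. The estimated outcome is a number 2.8 percentage points higher from compound 1 to compound 4 (within the scatter). For compound 4 the expected growth inhibition is 51%, with an estimated range of 37% to 66%.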

Compound 4, percent growth inhibition at one concentration: 24.6%
For compound 4 the middle estimate is 26.4 percentage points above the measured one, outside the stated range (below it).
By their numbers in this assay, from the lowest: compound 4; then compound 1; then compounds 3 and 2 (each within the scatter of the next).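

In this assay, fluoro in place of chloro on an aromatic carbon, para to a large group, gives a number 23.6 percentage points lower from compound 1 to compound 4 (beyond the scatter), so on the core of compound 1 this one position is sensitive to which halogen it carries. The earlier step, a number 5.5 percentage points lower from compound 2 to compound 3 (within the scatter), could have suggested that the aromatic group on the sulfur tolerates change, but that pair has a different core and differs in other groups, so it did not test this swap. The new pair isolates a single change, with one heavy atom leaving, one entering and the rest of the molecule unchanged, yet nothing available here explains why the number moves.

On these data alone, whether bromo or methyl in this place would keep the number near that of compound 1, take it lower or raise it remains open, as does the effect of an amine there. The compounds shown also leave open whether 4-chlorophenyl and 4-fluorophenyl would differ in the same way on the core of compound 3.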